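Replacing 1,3-dimethyl-1H-pyrazol-5-yl with 2-methylpyridin-3-yl on the shared core

This account rests on a few compounds, and the source may have more. Where it says the series, first, only, none or still open, it means among the compounds named here.

Values in a physicochemical assay for lipophilicity, using the shake flask method, in phosphate buffer, measured as octanol-water partition, with a stated time of 30 min, at pH 7.4 (on this read-out lower numbers stand for lower lipophilicity and higher numbers for higher lipophilicity), for three compounds
Compound 1 `O=C1CCCN1c1cnc(NCc2c(F)ccc3c2CCO3)c2cn[nH]c(=O)c12` gives 1.8
Compound 2 `CC(=O)N1CCC(c2cnc(NCc3c(F)ccc4c3CCO4)c3cn[nH]c(=O)c23)CC1` gives 2.9
Compound 3 `Cc1cc(-c2cnc(NCc3c(F)ccc4c3CCO4)c3cn[nH]c(=O)c23)n(C)n1` gives 3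

In this assay compound 3 stands level with compound 2, and well clear of compound 1. The large move is a number 1.20 log units higher from compound 1 to compound 3 (beyond the scatter) while a number 0.10 log units higher from compound 2 to compound 3 (within the scatter) stays small. Compound 4 `Cc1ncccc1-c1cnc(NCc2c(F)ccc3c2CCO3)c2cn[nH]c(=O)c12` comes next, with 2-methylpyridin-3-yl in place of 1,3-dimethyl-1H-pyrazol-5-yl on an aromatic carbon, and 2-methylpyridin-3-yl in place of 1,3-dimethyl-1H-pyrazol-5-yl on an aromatic carbon gives the count. Among the measured compounds shown here, no measured step makes this exact exchange. The nearest guide is the small gap between compound 2 and compound 3, seen in a number 0.10 log units higher from compound 2 to compound 3 (within the scatter) as one group gives way to another at this carbon. The expected change is a number 0.10 log units lower from compound 3 to compound 4 (within the scatter) and so none beyond the scatter is expected. Compound 4 is estimated at 2.9 with an expected range of 2.4 to 3.4 on this estimate.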

Compound 4, distribution coefficient: 3
Compound 4: middle estimate off by 0.10 log units, on the low side; measured number inside the range.
By their numbers in this assay, from the lowest: compound 1; then compounds 2, 3 and 4 (each within the scatter of the next).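

In this assay, compound 4 stands level with compound 3 (no change at the digits printed from compound 3 to compound 4 (within the scatter)), so going from a five-membered to a six-membered aromatic ring, and from 2 hydrogen-bond acceptors to 1, shows no step beyond the scatter at this carbon. Compound 4 is also level with the non-aromatic 1-acetylpiperidin-4-yl compound (a number 0.10 log units higher from compound 2 to compound 4 (within the scatter)), while only compound 1, with 2-oxopyrrolidin-1-yl, stands apart (a number 1.20 log units higher from compound 1 to compound 4 (beyond the scatter)). Nothing available gives a reason for this grouping.

From the compounds shown here alone, it remains open whether an amine or a carboxylic acid at this carbon would stay level with compound 2, compound 3 and compound 4, or fall nearer compound 1.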